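The compounds below may be only part of what the source reports. "The series", "measured", "known", "first", "only" and "open" are said of these compounds alone.

Measured so far in an ADME assay on HEK293 cells (Homo sapiens) for cytotoxicity, with a stated time of 72 h; a higher number here means that more compound is needed for the effect, a lower number that less compound is needed:
Compound 1, `O=C(Nc1cc(-c2nc3ccccc3s2)ccc1Cl)c1cc([N+](=O)[O-])ccc1Cl`, gives only a limit, > 25000 nM.
Compound 2, `O=C(Nc1nc(-c2ccc(Cl)cc2)cs1)c1cc([N+](=O)[O-])ccc1Cl`, gives 15000 nM.
Compound 3, `COc1ccc(-c2nc3ccccc3s2)cc1NC(=O)c1cc([N+](=O)[O-])ccc1Cl`, gives only a limit, > 25000 nM.

Compound 3 therefore stands at the limit of this assay, the same limit at which compound 1 sits, as the limit of > 25000 nM in this assay, at which 2 of the 3 values shown sit, records. Within the data shown here, the only step between measured compounds that differ in one place, a step that the two limits leave unreadable from compound 1 to compound 3, is of a size that cannot be read. Compound 2 differs from both of the others in more than one place and gives a number rather than a limit.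

Compound 4, `O=C(Nc1cc(-c2nc3ccccc3s2)ccc1F)c1cc([N+](=O)[O-])ccc1Cl`, is yet to be measured. It arises from compound 3 by fluoro in place of methoxy on an aromatic carbon. Chloro in compound 1 and methoxy in compound 3 both leave their compounds at the limit, so compound 4 with fluoro is expected to sit at or near that limit too. The expected step is then a step that the limit leaves unreadable from compound 3 to compound 4, none beyond the scatter. For compound 4 the estimate in this assay is 30000 nM, with a range from 12000 nM to 80000 nM.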

Compound 4, half-maximal effective concentration: > 25000 nM
Compound 4: no number, only a limit; the forecaster's own chance of this, stated with the estimate: 70%; the middle value is on the limit's open side.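

Compound 4 gives only a limit, as do compound 1 and compound 3, so no step among these three compounds can be read: the limit of > 25000 nM in this assay, at which 3 of the 4 values shown sit. The compounds shown leave open whether fluoro, chloro and methoxy at this place differ at all in cytotoxicity.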